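A few compounds are considered here, and "the series" means these few. Any claim that something is new, unique, unknown or untested is made for them only; others in the source may bear on it.

Series notes. In an assay on CHO cells for displacement of a labelled ligand from adenosine receptor A3 (Homo sapiens), read by scintillation counting, tested at 10 uM (a higher number here means more inhibition at the concentration tested (going by the name of the read-out), a lower number less inhibition), compound 1 `CC(C)(C)Cc1csc(N)c1C(=O)c1cccc(Cl)c1` gives 8%, compound 2 `CC(C)(C)Cc1c(-c2cccc(F)c2F)sc(N)c1C(=O)c1ccc(Cl)cc1` gives 1% and compound 3 `CC(C)(C)Cc1csc(N)c1C(=O)c1cccc(C(F)(F)F)c1` gives 1%. Compound 3 sits level with compound 2 at the digits shown, the two together the lowest of the three numbers; the only single step measured, a number 7 percentage points lower from compound 1 to compound 3 (within the scatter), stays within the scatter, as does the gap from compound 3 to compound 1.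

Compound 4 `CC(C)(C)Cc1c(Br)sc(N)c1C(=O)c1cccc(C(F)(F)F)c1` differs from compound 3 by bromo in place of hydrogen on an aromatic carbon. Going by the values given here, no measured step bears on this change; compound 2 carries a ring substituent in the same region of the core and reads low, like compound 3. The expected step of a number 2 percentage points higher from compound 3 to compound 4 (within the scatter) is therefore none beyond the scatter. Compound 4 is estimated at 3%, range -8% to 15%.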

Compound 4, a percentage reported as inhibition, at one concentration (the size of the read-out at that concentration, not a potency): 4%
Compound 4: middle estimate off by 1 percentage points, on the low side; the range from low to high includes it.
By their numbers in this assay, from the lowest: compounds 2, 3, 4 and 1 (each within the scatter of the next).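

Bromo on the aromatic carbon next to the ring sulfur gives the only direct reading at this position: in this assay the change is a number 3 percentage points higher from compound 3 to compound 4 (within the scatter). With trifluoromethyl on the other aromatic ring, replacing hydrogen with bromo here therefore leaves the number within the scatter. Nothing at hand bears on why this reading arises.

As far as these compounds go, whether an amine, a carboxylic acid or a longer chain at this position would give a reading beyond the scatter remains open. Also open, from the compounds shown here alone, is whether bromo gives the same result with chloro in place of trifluoromethyl.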